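This account rests on a few compounds, and the source may have more. Where it says the series, first, only, none or still open, it means among the compounds named here.

Working notes on the series. Three compounds carry results in an ADME assay on BHK cells (Mesocricetus auratus) for cytotoxicity, read by MTT assay, with a stated time of 96 h; a lower number here means that less compound is tolerated, a higher number that more compound is tolerated. Compound 1, `CCN(CC)CC(=O)Nc1ccc(-c2nc3cc(C(F)(F)F)ccc3n2C)cc1`, gives 16000 nM. Compound 3, `COc1ccc(-c2nc3cc(Cl)c(Cl)cc3[nH]2)cc1`, gives 18000 nM, which sits within the scatter of the result of compound 1, so the two are not told apart. Compound 2, `Fc1cccc(F)c1-c1nc2cc(Cl)c(Cl)cc2[nH]1`, gives only a limit, > 100000 nM. That limit is the limit of > 100000 nM in this assay, at which 1 of the 3 values shown sits. Of the two numbers shown, compound 1 holds the lower one, but with compound 3 inside the scatter nothing is made of the order.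

Compound 4, `CC(=O)Nc1ccc(-c2nc3cc(C(F)(F)F)ccc3n2C)cc1`, awaits measurement in this assay. It differs from compound 1 in one place: hydrogen in place of diethylamino on a saturated chain carbon bound to a carbonyl carbon. Among the measured compounds shown here, no pair of measured compounds differs in a single place, so no measured step shows what such a change does in this assay. The expectation is a step no larger than the scatter, with no direction to prefer. The estimated step is a 1.3-fold higher number from compound 1 to compound 4 (0.10 log units; within the scatter). For compound 4 the value in this assay is therefore expected near 20000 nM, inside a range from 8000 nM to 50000 nM.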

Compound 4, half-maximal cytotoxic concentration: > 100000 nM
Compound 4: no number, only a limit; the forecaster's own chance of this, stated with the estimate: 15%; at least 5.0-fold (0.69 log units) between middle value and limit.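

In this assay, the saturated chain carbon bound to a carbonyl carbon now has its first measured step: hydrogen in place of diethylamino gives an at least 6.2-fold higher number from compound 1 to compound 4 (0.79 log units; beyond the scatter). The shared core therefore does not set the result on its own, since the group at this one place moves it beyond the scatter. The value of compound 4 is a limit and not a number, so the step has a lower bound but no full size: the limit of > 100000 nM in this assay, at which 2 of the 4 values shown sit.

The compounds shown leave open whether this step belongs to the diethylamino group in particular or would follow from any sizeable group at this place. A smaller amine such as dimethylamino, a simple ethyl chain or a carboxylic acid on the same carbon would show which part of the group goes with the lower number of compound 1.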